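Replacing trifluoromethyl with pyridin-2-yl in compound 1

A few compounds are considered here, and "the series" means these few. Any claim that something is new, unique, unknown or untested is made for them only; others in the source may bear on it.

In a physicochemical assay for solubility (on this read-out higher numbers stand for higher solubility and lower numbers for lower solubility), compound 1 `C[C@H](Oc1ccc(S(C)(=O)=O)cc1C(=O)N1Cc2ccc(C(F)(F)F)cc2C1)C(F)(F)F` gives 1 ug/mL, the lowest of three numbers, while compound 2 `COc1cccc2c1CN(C(=O)c1cc(S(C)(=O)=O)ccc1O[C@@H](C)C(F)(F)F)C2` gives 85 ug/mL and compound 3 `C[C@H](Oc1ccc(S(C)(=O)=O)cc1C(=O)N1Cc2cccc(C#N)c2C1)C(F)(F)F` gives 259 ug/mL. Compound 4 `C[C@H](Oc1ccc(S(C)(=O)=O)cc1C(=O)N1Cc2ccc(-c3ccccn3)cc2C1)C(F)(F)F` differs from compound 1 as follows: pyridin-2-yl in place of trifluoromethyl on an aromatic carbon. In words, it carries pyridin-2-yl in place of trifluoromethyl on an aromatic carbon. For the measured compounds named here, the only measured step, a 3.0-fold higher number from compound 2 to compound 3 (0.48 log units; beyond the scatter), is modest and places cyano in place of methoxy on an aromatic carbon. Going by the values given here, that is a different exchange, so it bears only loosely here, and no measured step covers the change itself. A modest rise in this assay is expected, and the expected step is a 4.0-fold higher number from compound 1 to compound 4 (0.60 log units; beyond the scatter). Compound 4 is estimated at 4 ug/mL, with an expected range of 1 ug/mL to 25 ug/mL.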

Compound 4, solubility: 30 ug/mL
For compound 4 the middle estimate is 7.5-fold (0.88 log units) below the measured one; the whole stated range lies below it.
By their numbers in this assay, from the lowest: compound 1; then compound 4; then compound 2; then compound 3.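

In this assay, for the compounds shown here, pyridin-2-yl in place of trifluoromethyl on an aromatic carbon gives a 30-fold higher number from compound 1 to compound 4 (1.48 log units; beyond the scatter) and so a large step, whereas the only earlier step, a 3.0-fold higher number from compound 2 to compound 3 (0.48 log units; beyond the scatter) and a different exchange, was modest. The group at this carbon can therefore move the number strongly on the core of compound 1, and here a six-membered aromatic ring with more heavy atoms than trifluoromethyl does not lower it. From the compounds shown here alone, whether pyridin-3-yl, an amine or a carboxylic acid at this same carbon would move the number as far remains open. Nothing given here accounts for the size of this step.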